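A Piperidine Replaces a Pyrazole on the Acetamide Arm

The source may hold more compounds than are shown below. What is called first, only, known or untested is meant among the compounds shown, and "the series" means these compounds.

Measured compounds:
compound 1, `C[C@@H]1CN(c2sc(C(F)(F)F)nc2-c2nc3ccccc3[nH]2)CCN1C(=O)Cn1cc(Cl)cn1`: 251 nM
compound 2, `Cc1nc(C)n(CC(=O)N2CCN(c3sc(C(F)(F)F)nc3-c3nc4ccc(OC5CNC5)cc4[nH]3)C[C@H]2C)n1`: 580 nM
compound 3, `Cc1nc(C)n(CC(=O)N2CCN(c3sc(C(F)(F)F)nc3-c3nc4ccc(C(C)(C)O)c(F)c4[nH]3)C[C@H]2C)n1`: 628 nM

Of the compounds shown here, three have been measured in a functional assay on Venous blood for antagonist activity at C-X-C chemokine receptor type 3 (Homo sapiens), read by flow cytometry, with a stated time of 30 min, in the presence of a further agent that is not named here; a lower number here means a stronger inhibitor, a higher number a weaker inhibitor. Compound 1 gives 251 nM. Compound 2 gives 580 nM, and compound 3 gives 628 nM. Compound 1 stands lowest of the three, and its gaps to compound 2 and to compound 3 both lie beyond the usual scatter, so it is the strongest inhibitor among them. Going by the values given here, compounds 2 and 3 differ from compound 1 in more than one place, so no step between measured compounds that changes a single site is available to guide the next prediction.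

Compound 4, `C[C@@H]1CN(c2sc(C(F)(F)F)nc2-c2nc3ccccc3[nH]2)CCN1C(=O)CN1CCC(F)(F)CC1`, differs from compound 1 at one site only: 4,4-difluoropiperidin-1-yl in place of 4-chloro-1H-pyrazol-1-yl on a saturated chain carbon bound to a carbonyl carbon. Nothing measured here shows the effect of this exchange on the shared core. Among the compounds with values here, with no comparable step to lean on, the author expects a modest change, somewhat toward a higher number, and the step from compound 1 to compound 4 is expected to be a 1.6-fold higher number from compound 1 to compound 4 (0.20 log units; within the scatter) in this assay . Compound 4 is therefore expected to give about 400 nM, with a plausible range from 130 nM to 1300 nM.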

Compound 4, half-maximal inhibitory concentration: 2430 nM
The estimate for compound 4 lay 6.1-fold (0.78 log units) below the measured number; the whole stated range lies below it.
By their numbers in this assay, from the lowest: compound 1; then compounds 2 and 3 (each within the scatter of the next); then compound 4.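

At this place, on a saturated chain carbon bound to a carbonyl carbon, 4,4-difluoropiperidin-1-yl in place of 4-chloro-1H-pyrazol-1-yl gives a 9.7-fold higher number from compound 1 to compound 4 (0.99 log units; beyond the scatter) in this assay, a step beyond the usual scatter. Going by these compounds alone, the earlier compounds offered no single-site step, so this is the first direct sign that, with the shared core held fixed, the group at this place alone can move the number, and that these two groups are not interchangeable here. The change replaces one five-membered aromatic ring with 2 hetero atoms by one six-membered non-aromatic ring with 1 hetero atom, and chlorine by two fluorines, all at once, and nothing available gives a measured reason for the step.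

Going by these compounds, it remains open whether the ring or its halogens account for the step. A plain piperidin-1-yl or a morpholin-4-yl on the same chain, or a 1H-pyrazol-1-yl without its chlorine, would help to separate the two, and none of these stands among the compounds shown.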